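Adding Chloro and Trifluoromethyl to the Phenyl Arm

This account rests on a few compounds, and the source may have more. Where it says the series, first, only, none or still open, it means among the compounds named here.

Measured so far:
- Compound 1, `CC/C(=C(/c1ccc(/C=C/C(=O)O)cc1)c1cc2ccccc2[nH]1)c1ccccc1`: 108 nM
- Compound 2, `CC/C(=C(/c1ccc(/C=C/C(=O)O)cc1)c1cc2ccccc2[nH]1)c1ccccc1Cl`: 42 nM

Compound 2 gives the lowest of the two numbers in a functional assay on MCF7 cells (Homo sapiens) for inhibition; a lower number here means a stronger inhibitor, a higher number a weaker inhibitor; its nearest neighbour is compound 1, and the step of a 2.6-fold lower number from compound 1 to compound 2 (0.41 log units; beyond the scatter) lies beyond the scatter. Compound 3, `CC/C(=C(/c1ccc(/C=C/C(=O)O)cc1)c1cc2ccccc2[nH]1)c1ccc(Cl)cc1C(F)(F)F`, has not yet been measured. It differs from compound 2 in one place: 4-chloro-2-(trifluoromethyl)phenyl in place of 2-chlorophenyl on a double-bonded chain carbon bound to a double-bonded chain carbon and a saturated chain carbon. Among the measured compounds shown here, the only measured step that bears on this change is a 2.6-fold lower number from compound 1 to compound 2 (0.41 log units; beyond the scatter), in which a chloro entered the phenyl arm and the number fell modestly. For the measured compounds named here, compound 3 keeps a chloro on that ring and adds a trifluoromethyl, so a further change of similar or smaller size is plausible, but no measured pair shows what a trifluoromethyl does here. For compound 3 a number near that of compound 2 is therefore expected, a 1.2-fold higher number from compound 2 to compound 3 (0.08 log units; within the scatter), within the scatter. The estimate for compound 3 is 50 nM, with a range from 15 nM to 170 nM.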

Compound 3, half-maximal inhibitory concentration: 4 nM
The estimate for compound 3 lay 13-fold (1.10 log units) above the measured number; the whole stated range lies above it.
By their numbers in this assay, from the lowest: compound 3; then compound 2; then compound 1.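

The 2-chlorophenyl arm was not close to the limit of what this position can give in this assay: the change to 4-chloro-2-(trifluoromethyl)phenyl brings an 11-fold lower number from compound 2 to compound 3 (1.02 log units; beyond the scatter), a large step where the first chloro gave only a modest one. Measured against the bare phenyl, the same arm gives a 27-fold lower number from compound 1 to compound 3 (1.43 log units; beyond the scatter) and shows that this double-bonded chain carbon accepts an arm of 11 heavy atoms with a clear gain over arms of fewer atoms. Nothing available explains this gain.

The arm of compound 3 differs from that of compound 2 in both its chloro and its trifluoromethyl, so the share of each in the gain cannot be separated. On these data alone, whether a 2-(trifluoromethyl)phenyl arm without the chloro, or a nitrile or methoxy group in place of the trifluoromethyl, would give a similarly low number remains open.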